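A few compounds are considered here, and "the series" means these few. Any claim that something is new, unique, unknown or untested is made for them only; others in the source may bear on it.

Measured so far:
- compound 1 `CN(C)C12CC(c3ccccc3)C(CN(C(=O)CCN3CCCCC3)C1)C(c1ccccc1)C2`: 12400 nM
- compound 2 `CN(C)C12CC(c3ccccc3)C(CN(CCN3CCCCC3)C1)C(c1ccccc1)C2`: 2920 nM

In an ADME assay on L6 cells (Rattus norvegicus) for cytotoxicity, read by resazurin assay, with a stated time of 72 h (on this read-out lower numbers stand for stronger inhibition and higher numbers for weaker inhibition), compound 2 has the lower of the two numbers, at 2920 nM, so it is the stronger inhibitor of this pair. Compound 3 `CN1CCN(CCCN2CC3C(c4ccccc4)CC(N(C)C)(CC3c3ccccc3)C2)CC1` has not yet been measured. It keeps the shared core and alters the side chain: (4-methylpiperazin-1-yl)methyl in place of piperidin-1-yl on a saturated chain carbon, two bonds along the chain from an amine nitrogen in a ring. Put another way, 2-(piperidin-1-yl)ethyl becomes 3-(4-methylpiperazin-1-yl)propyl on the amine nitrogen in a ring.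

Among the measured compounds shown here, only one measured step touches this side chain, a 4.2-fold lower number from compound 1 to compound 2 (0.63 log units; beyond the scatter). That step took away a carbonyl and left the piperidine ring unchanged, so it is a loose guide at best. For the measured compounds named here, no measured pair shows this exchange, so no clear shift in either direction is expected. The expected change is a 1.4-fold higher number from compound 2 to compound 3 (0.14 log units; within the scatter). For compound 3 the estimated value is 4000 nM, with an expected range of 1500 nM to 12000 nM.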

Compound 3, half-maximal inhibitory concentration: 200 nM
Compound 3: the middle estimate sits 20-fold (1.30 log units) above what was measured; the measured number lies below the stated range.
By their numbers in this assay, from the lowest: compound 3; then compound 2; then compound 1.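

In this assay, among the compounds shown here, the side chain on the ring amine nitrogen turns out to matter far more than the one earlier step suggested: going from 2-(piperidin-1-yl)ethyl to 3-(4-methylpiperazin-1-yl)propyl gives a 15-fold lower number from compound 2 to compound 3 (1.16 log units; beyond the scatter). Replacing the (2-(piperidin-1-yl)ethyl)carbonyl group with this same 3-(4-methylpiperazin-1-yl)propyl group gives a 62-fold lower number from compound 1 to compound 3 (1.79 log units; beyond the scatter), a much larger step than removing the carbonyl alone, which gave a 4.2-fold lower number from compound 1 to compound 2 (0.63 log units; beyond the scatter). Nothing available explains why this exchange has so large an effect.

This single exchange alters both the chain and the ring, so the compounds shown leave open which of the two accounts for the shift. A 3-(piperidin-1-yl)propyl group or a 2-(4-methylpiperazin-1-yl)ethyl group on the same nitrogen would separate the two.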